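Plasma stability of compound 4 beside its measured neighbours

This account rests on a few compounds, and the source may have more. Where it says the series, first, only, none or still open, it means among the compounds named here.

In an ADME assay on a cell-free system (plasma, Rattus norvegicus) for metabolic stability, read by LC-MS, with a stated time of 1 h, at 37 degrees C, tested at 100 uM (a higher number here means that more of the compound is left, a lower number that less of the compound is left), the three measured compounds read as follows:

Compound 1, `O=C(O)c1ccc(-c2cccc(COc3ccc4c(c3)CN(C3CCCC3)C4=O)c2)c(Cl)c1`: 100%
Compound 2, `Cn1sc2cc(OCc3cccc(-c4ccc(Cl)c(C(=O)O)c4)c3)ccc2c1=O`: 100%
Compound 3, `O=C(O)c1ccc(Cl)c(-c2cccc(COc3ccc4c(c3)CN(C3CCCC3)C4=O)c2)c1`: 100%

Compound 2 stands level with compounds 1 and 3 at the digits shown; its nearest neighbour is compound 1, with no change within the scatter, and its furthest is compound 3, again with no change within the scatter. Among the measured compounds shown here, the only step between measured compounds that differ in one place is no change at the digits printed from compound 1 to compound 3 (within the scatter), and it touches a different part of the molecule, the carboxy-chlorophenyl group, not the place altered here.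

Compound 4, `CC(C)CCn1sc2cc(OCc3cccc(-c4ccc(Cl)c(C(=O)O)c4)c3)ccc2c1=O`, differs from compound 2 in one respect: isobutyl in place of hydrogen on a saturated chain carbon bound to an aromatic nitrogen. For the measured compounds named here, no measured step bears on this change, so the expectation rests only on the observation that every measured compound, whatever its substitution, is fully recovered in this assay. On that basis compound 4 is expected to give 97%, with a range from 82% to 100%. The step of a number 3 percentage points lower from compound 2 to compound 4 (within the scatter) is therefore expected to be none beyond the scatter, with the lower end of the range allowing for a modest loss that the data cannot rule out.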

Compound 4, percent of the compound remaining: 91%
Compound 4: middle estimate off by 6 percentage points, on the high side, within the range that was stated.
By their numbers in this assay, from the lowest: compounds 4, 1, 2 and 3 (each within the scatter of the next).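

In this assay, the change of methyl to isopentyl on the aromatic nitrogen, which is the entry of isobutyl on a saturated chain carbon bound to an aromatic nitrogen, reads as a number 9 percentage points lower from compound 2 to compound 4 (within the scatter) and is the first step shown at this place. Among the compounds shown here, the only earlier step lay on the carboxy-chlorophenyl group, so this one adds that a chain with 4 more heavy atoms, no ring and no hydrogen-bond donors or acceptors can sit at this place with compound 4 still within the scatter of compound 2. No measurement shown here accounts for the reading of compound 4, and nothing on hand speaks to how the compound behaves in this assay at this place.

On these data alone, what remains open is whether a longer chain than isopentyl, or a chain ending in an amine or a hydroxyl group, would stay within the scatter of compound 2 at this place. Also open, as far as these compounds go, is whether the same change of methyl to isopentyl gives a like step with the chlorine and the carboxylic acid set differently on the outer phenyl ring.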